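This account rests on a few compounds, and the source may have more. Where it says the series, first, only, none or still open, it means among the compounds named here.

Three analogues built on a shared core have been measured in a functional assay on PC-3 cells (Homo sapiens) for cytotoxicity, read by MTT assay, with a stated time of 48 h; a lower number here means a stronger inhibitor, a higher number a weaker inhibitor. Compound 1 `Cc1ccc(C(=O)N2N=C(c3cc4ccccc4oc3=O)CC2c2ccccc2)cc1` gives 13200 nM, compound 2 `CCC(=O)N1N=C(c2cc3ccccc3oc2=O)CC1c1ccccc1` gives 4370 nM, and compound 3 `O=C(CNC1CCCCC1)N1N=C(c2cc3ccccc3oc2=O)CC1c1ccccc1` gives 48500 nM. Compound 3 thus stands highest of the three numbers. Two steps lead to it: a 3.7-fold higher number from compound 1 to compound 3 (0.57 log units; beyond the scatter) and an 11-fold higher number from compound 2 to compound 3 (1.05 log units; beyond the scatter). The remaining step, a 3.0-fold lower number from compound 1 to compound 2 (0.48 log units; beyond the scatter), runs the other way.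

Compound 4 `CCN(CC)C1CCN(CC(=O)N2N=C(c3cc4ccccc4oc3=O)CC2c2ccccc2)CC1` carries 4-(diethylamino)piperidin-1-yl in place of cyclohexylamino on a saturated chain carbon bound to a carbonyl carbon. Of the measured steps, only an 11-fold higher number from compound 2 to compound 3 (1.05 log units; beyond the scatter) touches the same place, and there an amine-bearing group entering in place of a plain methyl cost dearly. Within the data shown here, no measured step exchanges one amine-bearing group for another at this position, so the data give no direction for swapping cyclohexylamino for 4-(diethylamino)piperidin-1-yl. The expectation is therefore a step of modest size at most, with its direction open, in this assay. Compound 4 is estimated at 40000 nM, within a range of 12000 nM to 130000 nM. This estimate corresponds to a 1.2-fold lower number from compound 3 to compound 4 (0.08 log units; within the scatter).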

Compound 4, half-maximal inhibitory concentration: 26100 nM
Compound 4: the middle estimate sits 1.5-fold (0.19 log units) above what was measured; low and high end bracket the measured number.
By their numbers in this assay, from the lowest: compound 2; then compounds 1, 4 and 3 (each within the scatter of the next, the first and the last beyond it).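

In this assay the exchange of cyclohexylamino for 4-(diethylamino)piperidin-1-yl on a saturated chain carbon bound to a carbonyl carbon gives a 1.9-fold lower number from compound 3 to compound 4 (0.27 log units; within the scatter) and so the two amine-bearing groups, despite their different heavy-atom counts, cannot be told apart here. Compound 4 still shows a 6.0-fold higher number from compound 2 to compound 4 (0.78 log units; beyond the scatter) and thus a second amine-bearing group also gives a higher number than the methyl of compound 2, while a 2.0-fold higher number from compound 1 to compound 4 (0.30 log units; within the scatter) leaves no separation from the 4-methylphenyl group of compound 1. Nothing available explains the higher numbers seen with these amine-bearing groups.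

As far as these compounds go, whether a small open-chain amine such as dimethylamino would behave like these two groups remains open. So does whether a carboxylic acid or a plain longer alkyl chain at this place would stay nearer compound 2.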